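Replacing Benzylsulfanyl with Amino on a Cyclic Nucleotide Core

This account rests on a few compounds, and the source may have more. Where it says the series, first, only, none or still open, it means among the compounds named here.

Measured compounds:
compound 1, `[N-]=[N+]=Nc1nc2c(N)ncnc2n1[C@@H]1O[C@@H]2COP(=O)(O)O[C@H]2[C@H]1O`, 633%
compound 2, `Nc1ncnc2c1nc(SCc1ccccc1)n2[C@@H]1O[C@@H]2COP(=O)(O)O[C@H]2[C@H]1O`, 195%

The two compounds share a core and differ only in the group on one aromatic carbon of the five-membered ring. In a functional assay on the whole organism for activation, with Mus musculus as the target, with stated times of 14 days and 2 h, at a dose of 30 mg/kg by the intravenous route (a lower number here means a weaker effect, a higher number a stronger effect of the compound at the dose given), compound 1 gives 633%, while compound 2 gives 195%. Among the measured compounds shown here, the single measured step, a number 438 percentage points lower from compound 1 to compound 2 (beyond the scatter), follows the exchange of azido for benzylsulfanyl. For the measured compounds named here, compound 2 thus stands lowest of the two numbers, with compound 1 as its only neighbour and well beyond the scatter above it.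

Compound 3, `Nc1ncnc2c1nc(N)n2[C@@H]1O[C@@H]2COP(=O)(O)O[C@H]2[C@H]1O`, is not yet measured. Its change from compound 2 is amino in place of benzylsulfanyl on an aromatic carbon. Going by the values given here, the one step that bears on this is a number 438 percentage points lower from compound 1 to compound 2 (beyond the scatter), where the large benzylsulfanyl group arrived and the number fell sharply. As far as these compounds go, the move to amino removes that same group again, so a step upward in this assay is expected, though how far amino tracks azido is unknown. The estimate for compound 3 is 400%, in a range from 150% to 700%, which means an expected step of a number 205 percentage points higher from compound 2 to compound 3 (beyond the scatter).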

Compound 3, a percentage reported as activity, at one dose (the size of the read-out at that dose, not a potency): 607%
For compound 3 the middle estimate is 207 percentage points below the measured one; measured number inside the range.
By their numbers in this assay, from the lowest: compound 2; then compound 3; then compound 1.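

In this assay, the exchange of benzylsulfanyl for amino on this aromatic carbon gives a number 412 percentage points higher from compound 2 to compound 3 (beyond the scatter) and so restores nearly all of the ground lost with compound 2. The high read-out is therefore not tied to azido alone, since a second, different group at this position reaches a similar level. The remaining difference between the two is a number 26 percentage points lower from compound 1 to compound 3 (beyond the scatter) and is beyond the scatter, so azido keeps compound 1 the highest of the three, but this gap is far smaller than either step involving benzylsulfanyl. Nothing available here accounts for these differences in the whole-organism read-out.

The three compounds do not separate the sulfur atom from the benzyl group, so a methylsulfanyl group or a phenyl group at the same carbon would be needed to show which part goes with the lower number. They also leave open how the read-out responds to a methylamino group, a hydroxyl group or a longer alkylamine chain in place of amino, and whether any such group could match or pass azido.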